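The source may report more compounds than this note shows. Statements on the series, on what has been measured and on what is new or still open speak of the compounds shown alone.

Values in an ADME assay on HepG2 2.2.15 cells (Homo sapiens) for cytotoxicity; on this read-out lower numbers stand for higher toxicity in this test and higher numbers for lower toxicity in this test:
- compound 1 `O=C(OCCc1c(-c2ccccc2Cl)c2cc(Cl)ccc2[nH]c1=O)C1CCCCC1`: 38000 nM
- compound 2 `O=C(OCCc1c(-c2ccccc2Cl)c2cc(Cl)ccc2[nH]c1=O)c1ccccc1`: 43000 nM

Compound 2, at 43000 nM, cannot be told apart from compound 1. Among the compounds with values here, the only measured step is a 1.1-fold higher number from compound 1 to compound 2 (0.05 log units; within the scatter), so the two numbers sit together within the scatter, and neither stands out in this assay.

The next compound is compound 3 `O=C(OCCc1c(-c2ccccc2Cl)c2cc(Cl)ccc2[nH]c1=O)c1ccc([N+](=O)[O-])cc1`, which has nitro in place of hydrogen on an aromatic carbon, para to a large group: phenyl to 4-nitrophenyl on the ester carbonyl. The counted difference is nitro in place of hydrogen on an aromatic carbon.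

Within the data shown here, only one measured step bears on this change. It touches the same part of the molecule, the group on the carbonyl carbon, but it swaps a whole ring and does not add a substituent. That step, a 1.1-fold higher number from compound 1 to compound 2 (0.05 log units; within the scatter), shows that this part of the molecule has tolerated one change in this assay without a visible shift. Among the measured compounds shown here, no measured compound carries nitro, so the support is thin. No step beyond the scatter is expected, and the expected step is a 1.1-fold lower number from compound 2 to compound 3 (0.05 log units; within the scatter). The estimate for compound 3 is 38000 nM, with an expected range of 17000 nM to 80000 nM.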

Compound 3, half-maximal cytotoxic concentration: 1600000 nM
Beside the measured number, compound 3's estimate is 42-fold (1.62 log units) below it; measured number above the stated range.
By their numbers in this assay, from the lowest: compounds 1 and 2 (each within the scatter of the next); then compound 3.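

In this assay, the group on the ester carbonyl is not the silent place that the exchange of cyclohexyl for phenyl suggested. Nitro in place of hydrogen on the aromatic carbon, para to a large group, gives a large step towards lower toxicity in this test (a 37-fold higher number from compound 2 to compound 3 (1.57 log units; beyond the scatter)), and 4-nitrophenyl in place of cyclohexyl on the carbonyl carbon gives a large step in the same direction (a 42-fold higher number from compound 1 to compound 3 (1.62 log units; beyond the scatter)), so this part of the molecule can move the number strongly even though changing the ring alone left it within the scatter. Nothing measured here explains why this one substitution has so large an effect.

Still open, from the compounds shown here alone, is whether the step belongs to nitro itself or would also follow other groups on the same aromatic carbon, such as an amine, a methoxy group or a chlorine. Also open, going by these compounds, is whether the step in this assay would survive a change in the link to the shared core, for example an amide in place of the ester.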